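Swapping phenyl for benzyl in compound 3

A few compounds are considered here, and "the series" means these few. Any claim that something is new, unique, unknown or untested is made for them only; others in the source may bear on it.

In a functional assay on a cell-free system (plasma, Homo sapiens), with a stated time of 3 min (on this read-out lower numbers stand for stronger inhibition and higher numbers for weaker inhibition), compound 1 (`O=C(NCc1cc(Cl)ccc1-n1cnnn1)[C@@H]1C[C@@H]2C[C@@H]2N1C(=O)[C@H](O)CC1CC1`) gives 1700 nM, compound 2 (`CC(C)(C)OC[C@@H](O)C(=O)N1[C@H](C(=O)NCc2cc(Cl)ccc2-n2cnnn2)C[C@@H]2C[C@@H]21`) gives 500 nM and compound 3 (`O=C(NCc1cc(Cl)ccc1-n1cnnn1)[C@@H]1CC=NN1C(=O)[C@H](O)c1ccccc1`) gives 840 nM. Compound 3 thus lies within the usual scatter of compound 2, while its number is lower than that of compound 1, just beyond the scatter. Compound 4 (`O=C(NCc1cc(Cl)ccc1-n1cnnn1)[C@@H]1CC=NN1C(=O)[C@H](O)Cc1ccccc1`) has benzyl in place of phenyl on a saturated chain carbon bound to a carbonyl carbon and an oxygen on a saturated carbon. Among the compounds with values here, no measured step makes this exact change. The closest guide is a 3.4-fold lower number from compound 1 to compound 2 (0.53 log units; beyond the scatter), a modest step in which tert-butoxy replaces cyclopropyl on a similar side chain, though on the core of compound 1 rather than that of compound 3. This single step suggests only a small shift at most, and its direction is weakly supported. The expected step is a 1.4-fold lower number from compound 3 to compound 4 (0.15 log units; within the scatter), slightly downward but not beyond the scatter. For compound 4 the estimated value is 600 nM, with an expected range of 200 nM to 1800 nM.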

Compound 4, half-maximal inhibitory concentration: 1400 nM
Compound 4: middle estimate off by 2.3-fold (0.37 log units), on the low side; the range from low to high includes it.
By their numbers in this assay, from the lowest: compounds 2, 3, 4 and 1 (each within the scatter of the next, the first and the last beyond it).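

In this assay, putting benzyl in place of phenyl, on a saturated chain carbon bound to a carbonyl carbon and an oxygen on a saturated carbon, gives a 1.7-fold higher number from compound 3 to compound 4 (0.22 log units; within the scatter), so the two compounds cannot be told apart at this level of precision. Within the data shown here, this is the first direct reading of this position on the shared core of compound 3 and compound 4, as the earlier step concerned a different group pair on the core of compound 1. It shows that, for this one pair, the aromatic ring can sit one carbon further out with no difference beyond the scatter, and nothing measured here offers an explanation.

Still open, from the compounds shown here alone, is how a longer chain, such as 2-phenylethyl, or a carboxylic acid would read at this place. Also open, going by these compounds, is whether the same swap would read alike on the core of compound 1.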